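The source may hold more compounds than are shown below. What is called first, only, known or untested is meant among the compounds shown, and "the series" means these compounds.

Measured so far:
Compound 1, `Cc1ccccc1-c1c(C(=O)N(C)Cc2ccccc2Cl)n(C)c(=O)c2ccccc12`, in an assay on IM-9 cells for binding affinity to Substance-P receptor (Homo sapiens) (on this read-out higher numbers stand for weaker inhibition and lower numbers for stronger inhibition), compound 1 gives 19 nM.
Compound 2, `Cc1cc(C)cc(CN(C)C(=O)c2c(-c3ccccc3C)c3ccccc3c(=O)n2C)c1`, compound 2 gives 32 nM.
Compound 3, `CN(Cc1ccccc1Cl)C(=O)c1c(-c2ccc(F)cc2)c2cccnc2c(=O)n1C`, compound 3 gives 32 nM.

Compound 1 and compound 2 share one core and differ only in the group on the benzylic carbon: 3,5-dimethylphenyl in place of 2-chlorophenyl on a saturated chain carbon bound to an amide-type nitrogen. This change produced a 1.7-fold higher number from compound 1 to compound 2 (0.23 log units; within the scatter), a step that stays within the usual scatter of repeated measurements, so the two compounds are read as level in this assay.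

Compound 3 carries a different core from compound 1; the difference between the two cores is not broken down here. What the values show is that compound 3 and compound 2 stand level at the digits printed, and that compound 1 lies a small, within-scatter distance lower.

Compound 4, `Cc1cc(C)cc(CN(C)C(=O)c2c(-c3ccc(F)cc3)c3cccnc3c(=O)n2C)c1`, is the partner of compound 3 in the same change: 3,5-dimethylphenyl in place of 2-chlorophenyl on a saturated chain carbon bound to an amide-type nitrogen. The place is described in the same words for both pairs, so this is the same change that was made from compound 1 to compound 2. On that basis the expected step is a 1.7-fold higher number from compound 3 to compound 4 (0.24 log units; within the scatter), resting on the step of a 1.7-fold higher number from compound 1 to compound 2 (0.23 log units; within the scatter) seen once, with the caution that a single earlier instance on a different core supports only a loose expectation. Compound 4 is therefore estimated at 55 nM in this assay, with a likely range from 25 nM to 130 nM.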

Compound 4, half-maximal inhibitory concentration: 5.1 nM
The estimate for compound 4 lay 11-fold (1.03 log units) above the measured number; measured number outside the range, below it.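

On the core of compound 3, putting 3,5-dimethylphenyl in place of 2-chlorophenyl on the saturated chain carbon bound to the amide-type nitrogen gave a 6.3-fold lower number from compound 3 to compound 4 (0.80 log units; beyond the scatter) in this assay, so this single change separates the two compounds clearly on that core. The earlier pair gave no such separation, and the change therefore did not carry over as one fixed step from the core of compound 1 to the core of compound 3: the same change on two cores in this assay, a 1.7-fold higher number (0.23 log units; within the scatter) from compound 1 to compound 2 and a 6.3-fold lower number (0.80 log units; beyond the scatter) from compound 3 to compound 4, 11-fold (1.02 log units) apart, beyond the scatter of two such steps. This shows that the effect of the swap depends on the core it is made on, at least for these two pairs, but with one pair per core it does not show which feature of the cores matters, nor how the change would behave on any further core.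

The compounds shown leave open how a benzyl group carrying trifluoromethyl or methoxy groups in place of the two methyl groups would read on either core. They also leave open whether the 2-chlorobenzyl to 3,5-dimethylbenzyl change on a third core would follow the pattern of the core of compound 1, that of the core of compound 3, or neither.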